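A few compounds are considered here, and "the series" means these few. Any claim that something is new, unique, unknown or untested is made for them only; others in the source may bear on it.

Measured so far in a functional assay on HCT-15 cells (Homo sapiens) for antiproliferative activity, read by sulforhodamine B assay; on this read-out lower numbers stand for stronger inhibition of growth and higher numbers for weaker inhibition of growth:
compound 1 `COc1cccc(OCCC(C)(C)C)c1C(=O)/C=C/c1ccc(O)cc1`: > 30000 nM
compound 2 `O=C(/C=C/c1ccc(O)cc1)c1c(O)cccc1OCc1ccccc1`: > 30000 nM
compound 3 `CC(C)(C)CCOc1cccc(O)c1C(=O)CCc1ccc(O)cc1`: > 30000 nM

Each of these values is a limit of the assay, not a number. Compound 2 stands at that limit. Compound 1 is reported at the same limit, and compound 3 likewise; all three shown values sit there (the limit of > 30000 nM in this assay, at which 3 of the 3 values shown sit). Among the measured compounds shown here, nothing in the measured set therefore separates one compound from another, and no measured step between them can be stated.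

Compound 4 `CC(C)CCOc1cccc(O)c1C(=O)/C=C/c1ccc(O)cc1` is to be measured in this assay. It differs from compound 2 in one place: isobutyl in place of phenyl on a saturated chain carbon bound to an oxygen on an aromatic ring. Compound 3 already carries a saturated chain of this kind on the ring oxygen, with the linker between the carbonyl and the phenol saturated, and it too ends at the limit. With every shown value at the limit (the limit of > 30000 nM in this assay, at which 3 of the 3 values shown sit), the expected step from compound 2 to compound 4 is none beyond the scatter, a step that the limit leaves unreadable from compound 2 to compound 4, as no measured step gives a direction to follow. Compound 4 is therefore expected at 40000 nM, within 10000 nM to 150000 nM, and most likely to be reported again only as a limit.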

Compound 4, concentration for 50% growth inhibition: 10600 nM
Beside the measured number, compound 4's estimate is 3.8-fold (0.58 log units) above it; low and high end bracket the measured number.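

In this assay, among the compounds shown here, isobutyl in place of phenyl on a saturated chain carbon bound to an oxygen on an aromatic ring gives an at least 2.8-fold lower number from compound 2 to compound 4 (0.45 log units; beyond the scatter), the first readable step and the first sign that this position can move the read-out at all. Compound 4, at 10600 nM, is the only compound shown with a number, so the change from benzyloxy to isopentyloxy brings the series onto the readable part of the scale. Compound 2 stays a limit of the assay and not a number, so the step gives only a minimum size, and the set still holds a single readable value: the limit of > 30000 nM in this assay, at which 3 of the 4 values shown sit.

As far as these compounds go, whether the gain follows from the loss of the phenyl ring or from the branched chain itself stays open, and a cyclohexyl group on the same chain carbon would separate the two. From the compounds shown here alone, how far the read-out can fall at this position is also open: a longer chain, or an amine or a carboxylic acid carried on the isopentyl chain, could go either way, and the finding so far rests on one pair only.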